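Same change on a second core: removing the sulfonamide arm

The compounds below may be only part of what the source reports. "The series", "measured", "known", "first", "only" and "open" are said of these compounds alone.

Measured so far:
compound 1 `CCCCS(=O)(=O)N[C@@H](CNC(=O)c1cc2cc(CCC3CCNCC3)sc2s1)C(=O)O`, 32 nM
compound 2 `O=C(O)CCNC(=O)c1cc2cc(CCC3CCNCC3)sc2s1`, 410 nM
compound 3 `CCCCS(=O)(=O)N[C@@H](CNC(=O)c1cc2sc(CCC3CCNCC3)cc2s1)C(=O)O`, 10 nM

In a functional assay for inhibition, with Homo sapiens as the target (on this read-out higher numbers stand for weaker inhibition and lower numbers for stronger inhibition), compound 3 gives the lowest number of the three, and its nearest neighbour in this assay is compound 1. Compound 1 and compound 3 are built from the same atoms joined differently; the difference between the two cores is not broken down here. Compound 1 and compound 2 differ in one place: hydrogen in place of (butylsulfonyl)amino on a saturated chain carbon bound to a carbonyl carbon and a saturated chain carbon. That single change produced a 13-fold higher number from compound 1 to compound 2 (1.11 log units; beyond the scatter).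

Compound 4 `O=C(O)CCNC(=O)c1cc2sc(CCC3CCNCC3)cc2s1` is not yet measured. It stands to compound 3 as compound 2 stands to compound 1: hydrogen in place of (butylsulfonyl)amino on a saturated chain carbon bound to a carbonyl carbon and a saturated chain carbon. The place is described in the same words for both pairs, so this is the same change made on a second core. The expectation for compound 4 rests on that one earlier step, and compound 4 is expected to show a 13-fold higher number from compound 3 to compound 4 (1.11 log units; beyond the scatter) in this assay, a step of about the size seen between compound 1 and compound 2. On that basis compound 4 is estimated at 130 nM, likely between 50 nM and 400 nM.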

Compound 4, half-maximal inhibitory concentration: 500 nM
Compound 4: the middle estimate sits 3.8-fold (0.59 log units) below what was measured; measured number above the stated range.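

In this assay, putting hydrogen in place of (butylsulfonyl)amino on the second core produced a 50-fold higher number from compound 3 to compound 4 (1.70 log units; beyond the scatter). For the compounds shown here, the change therefore raises the number on both cores, so its direction carries over, but its size does not, as the two steps set side by side show: the same change on two cores in this assay, a 13-fold higher number (1.11 log units; beyond the scatter) from compound 1 to compound 2 and a 50-fold higher number (1.70 log units; beyond the scatter) from compound 3 to compound 4, 3.9-fold (0.59 log units) apart, beyond the scatter of two such steps With only two pairs, this does not show why the size depends on the core, and it gives no reliable size for the same change on any further core.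

The compounds shown treat (butylsulfonyl)amino as a single unit, so they leave open how much of each step belongs to the butyl chain and how much to the sulfonyl group or its nitrogen. A plain amine or a (methylsulfonyl)amino group on that same saturated chain carbon, compared on both cores in this assay, could begin to separate these parts.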